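Chloro in place of hydrogen on the anilino ring

The source may hold more compounds than are shown below. What is called first, only, known or untested is meant among the compounds shown, and "the series" means these compounds.

Measured compounds:
compound 1 `COC(=O)c1c(Nc2ccccc2)sc(C(=O)c2ccc(C)cc2)c1C`, 9.35%
compound 2 `COC(=O)c1c(Nc2ccc(Cl)cc2)sc(C(=O)c2ccc(C)cc2)c1C`, "not active" (no number reported)
compound 3 `Cc1ccc(C(=O)c2sc(Nc3ccccc3)c(C(=O)O)c2C)cc1`, 5.13%

In a functional assay, with a stated time of 150 min, tested at 30 ug/mL (on this read-out lower numbers stand for a weaker effect and higher numbers for a stronger effect at the one concentration tested), compound 1 gives 9.35%. Compound 2 is reported as "not active" (no number reported), without a number. The acid that corresponds to compound 1 is compound 3, which gives 5.13% in this assay; the step of a number 4.2 percentage points lower from compound 1 to compound 3 (within the scatter) lies within the scatter, so compound 3 and compound 1 stand together, and compound 2 adds no number to place beside them.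

Compound 4 `Cc1ccc(C(=O)c2sc(Nc3ccc(Cl)cc3)c(C(=O)O)c2C)cc1` has not yet been measured. It differs from compound 3 by chloro in place of hydrogen on an aromatic carbon. For the measured compounds named here, no measured step covers this change on the acid; the only guide is the pair of esters, where compound 1 gives a small number and compound 2 none at all. That pair shows no sign of a gain from the chloro group, and compound 3 itself starts from a small number.

Compound 4 is therefore expected to give 3% in this assay, between 0% and 10%, and the expected step of a number 2.1 percentage points lower from compound 3 to compound 4 (within the scatter) is not thought to exceed the scatter.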

Compound 4, a percentage reported as activity, at one concentration (the size of the read-out at that concentration, not a potency): "not active" (no number reported)
No number was reported for compound 4; there is nothing to compare the estimate with.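

In this assay, for the compounds shown here, compound 4 gives "not active" (no number reported) and so no step from compound 3 to compound 4 can be read. Nothing shown here points to a cause for this result. The compounds shown leave open how far chloro in place of hydrogen changes the effect, since neither compound 2 nor compound 4 carries a number.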